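The source may hold more compounds than are shown below. What is called first, only, known or untested is meant among the compounds shown, and "the series" means these compounds.

Measured in a functional assay on A549 cells (Homo sapiens) for cytotoxicity, read by MTT assay, with a stated time of 24 h; on this read-out higher numbers stand for weaker inhibition and lower numbers for stronger inhibition:
- compound 1, `C=CC1=C(C(=O)NCc2ccccc2)C(c2ccc(OC)c(OC)c2)OC1`: > 100000 nM
- compound 2, `C=CC1=C(C(=O)NCCC)C(c2ccc(Cl)c(Cl)c2)OC1`: > 100000 nM

Both of these values are limits of this assay, not numbers: the compounds showed no measurable inhibition up to the highest concentration tested. Compound 2 therefore stands at the limit, and every value shown sits in the same place (the limit of > 100000 nM in this assay, at which 2 of the 2 values shown sit). For the measured compounds named here, with two limits and no step between them, the data give no ranking at all.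

Compound 3, `C=CC1=C(C(=O)Nc2ccccc2)C(c2ccc(Cl)c(Cl)c2)OC1`, differs from compound 2 by one change: phenyl in place of propyl on an amide-type nitrogen. Going by the values given here, no measured step tells how this assay responds to such a change. Among the compounds with values here, the only guide is that compound 2 itself gave no inhibition within the tested range, so compound 3 is expected to stay near that limit, with a step that the limit leaves unreadable from compound 2 to compound 3 that means no change beyond the scatter. The estimate for compound 3 is 150000 nM, within 40000 nM to 600000 nM.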

Compound 3, half-maximal inhibitory concentration: > 100000 nM
Compound 3: no number, only a limit (the forecaster's own chance of this, stated with the estimate: 75%); the middle value lies beyond the limit too.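

Compound 2 and compound 3 both reach only a limit in this assay, so the change from propyl to phenyl gives no readable step: the limit of > 100000 nM in this assay, at which 3 of the 3 values shown sit. The compounds shown leave open which structural change, if any, would bring a measurable inhibition of these cells.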